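Lengthening an amino chain on a weakly cytotoxic benzimidazole

The compounds below may be only part of what the source reports. "The series", "measured", "known", "first", "only" and "open" are said of these compounds alone.

Of the compounds shown here, two have been tested in an ADME assay on Vero cells (Chlorocebus sabaeus) for cytotoxicity, read by resazurin assay, with a stated time of 3 days; on this read-out lower numbers stand for stronger inhibition and higher numbers for weaker inhibition. Compound 1, `CCCC(C)OC(=O)Nc1cc2nc(C3CCCCC3)[nH]c2cc1N(CC)CC`, gives > 100 ug/mL in this assay, which is a limit of the assay rather than a number. Compound 2, `CN(C)c1cc2[nH]c(C3CCCCC3)nc2cc1NC(=O)c1cccc(Br)c1`, gives > 100 ug/mL in this assay, again a limit rather than a number. Where compound 2 stands can thus be said only in terms of the limit of > 100 ug/mL in this assay, at which 2 of the 2 values shown sit, and no step between measured compounds can be drawn from these two values.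

Compound 3, `CCN(CC)c1cc2[nH]c(C3CCCCC3)nc2cc1NC(=O)c1cccc(Br)c1`, differs from compound 2 by a single change: diethylamino in place of dimethylamino on an aromatic carbon. Going by the values given here, with no measured step to lean on, the expected step from compound 2 to compound 3 in this assay is a step that the limit leaves unreadable from compound 2 to compound 3, which is none beyond the usual scatter. Compound 3 is therefore estimated at 150 ug/mL in this assay, within a range from 60 ug/mL to 400 ug/mL.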

Compound 3, half-maximal inhibitory concentration: > 100 ug/mL
Compound 3 gave a limit, no number; the forecaster's own chance of this, stated with the estimate: 75%; the middle value lies beyond the limit too.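

No step can be read from compound 2 to compound 3, or from compound 1 to compound 3, because all three compounds sit at one limit of the assay: the limit of > 100 ug/mL in this assay, at which 3 of the 3 values shown sit. From the compounds shown here alone, whether diethylamino in place of dimethylamino shifts the value at all, and where each compound's true value lies, stays open.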